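Swapping a thiophene for a dienyl chain on the amide

The source may hold more compounds than are shown below. What is called first, only, known or untested is meant among the compounds shown, and "the series" means these compounds.

Measured so far:
- compound 1, `CCCCCCCCCCCCCCNC(=O)[C@@H](N)[C@@H](C)O`, 11000 nM
- compound 2, `CCCCCCCCNC(=O)[C@@H](NC(=O)c1cccs1)[C@@H](C)O`, 91900 nM
- compound 3, `CCCCCCCCNC(=O)[C@@H](NC(=O)c1nccc2ccccc12)[C@@H](C)O`, 66000 nM

All three compounds share a threonine-derived core carrying a long alkyl amide. In a functional assay on SiHa cells (Homo sapiens) for cytotoxicity, read by MTT assay, with a stated time of 48 h (a lower number here means a stronger inhibitor, a higher number a weaker inhibitor), compound 1 gives 11000 nM, compound 2 gives 91900 nM and compound 3 gives 66000 nM. Compound 2 has the highest number of the three. Its gap to compound 3 lies within the scatter of repeated measurements, so the two cannot be ranked against each other; its gap to compound 1 lies beyond the scatter, so compound 1 is the clearly stronger inhibitor of that pair.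

Compound 4, `C/C=C/C=C/C(=O)N[C@H](C(=O)NCCCCCCCC)[C@@H](C)O`, has not yet been measured. It differs from compound 2 in one place: penta-1,3-dien-1-yl in place of thiophen-2-yl on a carbonyl carbon. Among the compounds with values here, no measured pair shows this kind of change, so its effect is unknown here. The expectation is a small step, likely not beyond the scatter, in either direction. Compound 4 is therefore estimated at 70000 nM, with a range from 25000 nM to 200000 nM, which corresponds to an expected step of a 1.3-fold lower number from compound 2 to compound 4 (0.12 log units; within the scatter).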

Compound 4, half-maximal inhibitory concentration: 123000 nM
The estimate for compound 4 lay 1.8-fold (0.24 log units) below the measured number; measured number inside the range.
By their numbers in this assay, from the lowest: compound 1; then compounds 3, 2 and 4 (each within the scatter of the next).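

In this assay, placing penta-1,3-dien-1-yl instead of thiophen-2-yl on the carbonyl carbon gives a 1.3-fold higher number from compound 2 to compound 4 (0.13 log units; within the scatter). In this one pair, the aromatic ring and its sulfur atom can therefore give way to an open chain with two double bonds, with no change that can be told from the scatter of repeated measurements. Nothing measured here explains why the two groups give readings this close.

As far as these compounds go, whether an amine or a carboxylic acid on the group attached to this carbonyl would move the number beyond the scatter remains open. Compound 1 differs from the others in more than one place, having both a longer alkyl chain and no acyl group on its nitrogen, so the contribution of each feature to its value cannot be separated.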